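Hydroxy loss and a larger chain at the assay limit

This account rests on a few compounds, and the source may have more. Where it says the series, first, only, none or still open, it means among the compounds named here.

Values in a functional assay for inhibition, with Rattus norvegicus as the target; a higher number here means that more compound is needed for the effect, a lower number that less compound is needed:
- compound 1 `CSCC[C@H](NC(=O)c1ccc(CN[C@H](CO)CC2CCCCC2)cc1-c1ccccc1C)C(=O)O`: 190 nM
- compound 2 `CSCC[C@H](NC(=O)c1ccc(CN[C@H](C)CC2CCCCC2)cc1-c1ccccc1C)C(=O)O`: > 1000 nM (a limit)
- compound 3 `CC[C@H](CC1CCCCC1)NCc1ccc(C(=O)N[C@@H](CCSC)C(=O)O)c(-c2ccccc2C)c1`: > 1000 nM (a limit)

Compound 3 has no numerical value, only the limit > 1000 nM. Compound 3 thus stands at the limit of > 1000 nM in this assay, at which 2 of the 3 values shown sit.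

Compound 4 `CSCC[C@H](NC(=O)c1ccc(CN[C@H](CCCC(C)C)CC2CCCCC2)cc1-c1ccccc1C)C(=O)O` differs from compound 3 by isobutyl in place of hydrogen on a saturated chain carbon, three bonds along the chain from an amine nitrogen. Cut one bond further out, the same difference reads ethyl to 4-methylpentyl.

Within the data shown here, no measured step makes this change. The closest evidence is an at least 5.2-fold higher number from compound 1 to compound 2 (0.72 log units; beyond the scatter), with hydrogen in place of hydroxy, and an at least 5.2-fold higher number from compound 1 to compound 3 (0.72 log units; beyond the scatter), with methyl in place of hydroxy. Both steps lie beyond the scatter and point to higher numbers when the hydroxy is absent. Compound 4 also lacks that hydroxy. Among the measured compounds shown here, the only step that adds carbon without a hydroxy present is a step that the two limits leave unreadable from compound 2 to compound 3, so it gives no size or direction for chain growth.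

No clear gain in this assay is therefore expected, and compound 4 is expected to remain near the limit or to exceed it. The expected change is a step that the limit leaves unreadable from compound 3 to compound 4, which is not expected to be a clearly readable step. For compound 4 the estimated value is 2000 nM, with an expected range from 600 nM to 8000 nM.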

Compound 4, half-maximal effective concentration: 52 nM
The estimate for compound 4 lay 38-fold (1.59 log units) above the measured number, and the stated range ends above it.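

In this assay, a hydroxy is not needed on this saturated chain carbon: isopentyl in its place gives a 3.7-fold lower number from compound 1 to compound 4 (0.56 log units; beyond the scatter), although hydrogen and methyl in that place had both given higher numbers than the hydroxy. The earlier compounds shown here gave no readable effect of adding carbon here, whereas isopentyl in place of hydrogen now gives an at least 19-fold lower number from compound 2 to compound 4 (1.28 log units; beyond the scatter), and isobutyl in place of hydrogen, three bonds along the chain from the amine nitrogen, gives an at least 19-fold lower number from compound 3 to compound 4 (1.28 log units; beyond the scatter). Both of these steps start from a limit and fix only a bound on their size, and the step from compound 2 to compound 3 cannot be read: the limit of > 1000 nM in this assay, at which 2 of the 4 values shown sit.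

The compounds shown leave open how the number moves across the chains between ethyl and 4-methylpentyl, and whether a straight hexyl chain or a longer chain would read like the branched 4-methylpentyl. Also open, from the compounds shown here alone, is whether a chain that carries both the added carbons and a hydroxy, such as a 5-hydroxypentyl chain, would go lower than compound 4 or lose the effect.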